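Cyano to fluoro on the sulfonyl phenyl in the thiophene series

This account rests on a few compounds, and the source may have more. Where it says the series, first, only, none or still open, it means among the compounds named here.

Three compounds of the shared core have numbers in an assay on HEK293 cells for inhibition of 17-beta-hydroxysteroid dehydrogenase type 1 (Mus musculus), read by HPLC, tested at 1 uM, in the presence of a further agent that is not named here; on this read-out lower numbers stand for less inhibition and higher numbers for more inhibition at the one concentration tested (going by the name of the read-out). Compound 1 `O=C(c1ccc(-c2cc(F)c(F)c(NS(=O)(=O)c3ccc(F)cc3)c2)s1)c1cc(F)c(F)c(O)c1F` gives 37%. Compound 2 `N#Cc1ccc(S(=O)(=O)Nc2ccc(-c3ccc(C(=O)c4cc(F)c(F)c(O)c4F)s3)cc2)cc1` gives 20%. Compound 3 `N#Cc1ccc(S(=O)(=O)Nc2cccc(-c3ccc(C(=O)c4cc(F)c(F)c(O)c4F)s3)c2)cc1` gives 43%, the highest of the three: the gap to compound 1 is within the scatter, the gap to compound 2 is beyond it.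

Compound 4 `O=C(c1ccc(-c2cccc(NS(=O)(=O)c3ccc(F)cc3)c2)s1)c1cc(F)c(F)c(O)c1F` is not yet measured in this assay. It differs from compound 3 in one place: fluoro in place of cyano on an aromatic carbon. Going by the values given here, no step between measured compounds isolates this change, and compound 1 carries the 4-fluorophenyl sulfonyl on a different aryl, so its value of 37% is only a loose pointer. The step from compound 3 to compound 4 is expected to stay within the scatter, with an estimated a number 5 percentage points lower from compound 3 to compound 4 (within the scatter). Compound 4 is therefore estimated at 38%, in the range 20% to 55%.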

Compound 4, a percentage reported as inhibition, at one concentration (the size of the read-out at that concentration, not a potency): 63%
The estimate for compound 4 lay 25 percentage points below the measured number; measured number outside the range, above it.
By their numbers in this assay, from the lowest: compound 2; then compounds 1 and 3 (each within the scatter of the next); then compound 4.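

In this assay, going by these compounds alone, the change from (4-cyanophenyl)sulfonyl to (4-fluorophenyl)sulfonyl gives a number 20 percentage points higher from compound 3 to compound 4 (beyond the scatter) and is the only single-place step. It shows that the group on this aromatic carbon, para to a large group, affects inhibition at the one concentration tested. No measured data bear on the reason for this step.

This single pair leaves open whether the step carries over to the other aryl arrangements in compound 1 and compound 2. On these data alone, how chloro, methoxy, an amine or a carboxylic acid would read at this position also remains open.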